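The compounds below may be only part of what the source reports. "The series", "measured", "known", "first", "only" and "open" are said of these compounds alone.

The measured compounds so far:
compound 1 `CN(C)c1ccc(C2CCCN2Cc2ccc(-c3ccccc3[N+](=O)[O-])o2)cc1` gives 0.0158 h in an ADME assay on microsomes from liver (Mus musculus, strain CD-1) for metabolic stability, read by LC-MS, using NADPH, with a stated time of 60 min, tested at 1 uM; on this read-out higher numbers stand for a longer-lived compound and lower numbers for a shorter-lived compound;
compound 2 `O=[N+]([O-])c1ccccc1-c1ccc(CN2CCCC2c2cccc(N3CCCC3)c2)o1` gives 0.0935 h;
compound 3 `Cc1cc([N+](=O)[O-])ccc1-c1ccc(CN2CCCC2c2cccc(N(C)C)c2)o1` gives 0.07 h.

Of these three, compound 1 gives the lowest number, with compound 3 above it and compound 2 higher still, both by more than the usual scatter. Compound 4 `O=[N+]([O-])c1ccccc1-c1ccc(CN2CCCC2c2ccc(N3CCCC3)cc2)o1` has not yet been measured in this assay. It differs from compound 1 in one place: pyrrolidin-1-yl in place of dimethylamino on an aromatic carbon. Going by the values given here, no measured pair differs in exactly this way, so the step cannot be read from the data; compound 2 also carries pyrrolidin-1-yl but differs from compound 1 in more than one place. A small rise is expected, a 2.2-fold higher number from compound 1 to compound 4 (0.35 log units; beyond the scatter), barely beyond the scatter. For compound 4 the estimate is 0.035 h, with a range from 0.012 h to 0.09 h.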

Compound 4, half-life: 0.0445 h
Beside the measured number, compound 4's estimate is 1.3-fold (0.10 log units) below it, and the stated range covers the measured number.
By their numbers in this assay, from the lowest: compound 1; then compounds 4, 3 and 2 (each within the scatter of the next, the first and the last beyond it).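

In this assay, putting pyrrolidin-1-yl in place of dimethylamino on an aromatic carbon, para to a large group, gives a 2.8-fold higher number from compound 1 to compound 4 (0.45 log units; beyond the scatter). Going by these compounds alone, this is the first direct reading of this change, since the two compounds differ in this one place only. The step is modest but beyond the scatter, so at this position the five-membered ring goes with a longer half-life than the open dimethylamino group. As far as these compounds go, whether a piperidin-1-yl or morpholin-4-yl group in the same place would give a similar step stays open. No measurement at hand gives a reason for the rise.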